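The source may report more compounds than this note shows. Statements on the series, on what has been measured and on what is new or still open speak of the compounds shown alone.

In an ADME assay on a cell-free system (plasma, Homo sapiens) for metabolic stability, read by LC-MS (on this read-out lower numbers stand for a shorter-lived compound and higher numbers for a longer-lived compound), compound 1 (`CCCOC(=O)c1cccc(C(=O)Nc2cccc(-c3cc(C(=O)Nc4ccncc4F)ccc3CN)c2)c1`) gives < 0.0834 h, which is a limit of the assay and not a number. Compound 3 (`COC(=O)c1cccc(NC(=O)c2cccc(-c3cc(C(=O)Nc4ccncc4F)ccc3CN)c2)c1F`) gives < 0.0834 h, the same limit. Compound 2 (`NCc1ccc(C(=O)Nc2ccncc2F)cc1-c1cccc(C(=O)Nc2ccc(CC(=O)O)cc2)c1`) gives > 2 h, a limit at the long-lived end. Compound 1 therefore stands at the short-lived end of the results so far.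

Compound 4 (`COC(=O)c1ccc(C(=O)Nc2cccc(-c3cc(C(=O)Nc4ccncc4F)ccc3CN)c2)cc1`) differs from compound 1 in one place: 4-(methoxycarbonyl)phenyl in place of 3-(propoxycarbonyl)phenyl on a carbonyl carbon. Among the compounds with values here, the one measured step that bears on this change is an at least 23-fold lower number from compound 2 to compound 3 (1.37 log units; beyond the scatter), and it is large. It replaces 4-(carboxymethyl)phenyl with 2-fluoro-3-(methoxycarbonyl)phenyl, a group that also carries methoxycarbonyl. Compound 4 keeps a methoxycarbonyl group, and neither compound at the short-lived limit goes against a short half-life for it. Within the data shown here, no measured pair isolates the change from 3-(propoxycarbonyl)phenyl to 4-(methoxycarbonyl)phenyl, so the expectation remains loose. The estimated step is a step that the limit leaves unreadable from compound 1 to compound 4, which means no change beyond the scatter is expected. Compound 4 is expected at 0.07 h, with an estimated range from 0.03 h to 0.25 h.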

Compound 4, half-life: > 2 h
Compound 4 was reported as a limit; the forecaster's own chance of this, stated with the estimate: 75%; at least 28-fold (1.45 log units) between middle value and limit.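

Placing 4-(methoxycarbonyl)phenyl instead of 3-(propoxycarbonyl)phenyl on the carbonyl carbon gives an at least 23-fold higher number from compound 1 to compound 4 (1.37 log units; beyond the scatter) in this assay. Compound 4 still carries an ester, the methoxycarbonyl group, so an ester on this phenyl ring does not by itself go with a short half-life, and compound 4 is the exception among the esters shown. Both ends of this step are limits of the assay and not numbers, so its full size cannot be told: the limit of > 2 h in this assay, at which 2 of the 4 values shown sit.

This single change alters both the ester chain and the name's ring number, 3 to 4, and the compounds shown do not separate the two. A 4-(propoxycarbonyl)phenyl or a 3-(methoxycarbonyl)phenyl group on the same carbonyl carbon would tell them apart.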